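This account rests on a few compounds, and the source may have more. Where it says the series, first, only, none or still open, it means among the compounds named here.

Working notes on the series. Compound 1 `CC1(C)CC(C)(C)c2cc(NC(=O)Nc3ccc(OC(F)(F)F)cc3)ccc2O1` has been measured in a functional assay on A2780 cells (Homo sapiens) for inhibition, with a stated time of 72 h (a lower number here means a stronger inhibitor, a higher number a weaker inhibitor), and gives 4560 nM. Compound 2 `CCOC(=O)c1ccc(N/C(S)=N/c2ccc3c(c2)C(C)(C)CC(C)(C)O3)cc1` gives 4300 nM in this assay, and compound 3 `CC1(C)CC(C)(C)c2cc(NC(=S)Nc3ccc([N+](=O)[O-])cc3)ccc2S1` gives 3170 nM. The number for compound 1 sits within the usual scatter of repeated measurements of both compound 2 and compound 3, so no order among the three can be read from these numbers. Among the measured compounds shown here, the three compounds differ from one another in more than one place, and no single step between them has been computed.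

Compound 4 `CC1(C)CC(C)(C)c2cc(NC(=O)Nc3ccc(C(F)(F)F)cc3)ccc2O1` has not yet been measured. It differs from compound 1 in one place: trifluoromethyl in place of trifluoromethoxy on an aromatic carbon. For the measured compounds named here, no measured pair in this set shows this same change, so the size of its step cannot be taken from the numbers at hand. Since the three measured compounds give numbers close to one another, the step from compound 1 to compound 4 is expected to be small, a 1.1-fold lower number from compound 1 to compound 4 (0.04 log units; within the scatter), with no preferred direction beyond the scatter. On that basis compound 4 is estimated at 4200 nM in this assay, with a range from 2000 nM to 9000 nM.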

Compound 4, half-maximal inhibitory concentration: 3600 nM
Compound 4: the middle estimate sits 1.2-fold (0.07 log units) above what was measured; the measured number falls inside the stated range.
By their numbers in this assay, from the lowest: compounds 3, 4, 2 and 1 (each within the scatter of the next).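

In this assay the series now has a step that can be read at a single place: a 1.3-fold lower number from compound 1 to compound 4 (0.10 log units; within the scatter) for trifluoromethyl in place of trifluoromethoxy on an aromatic carbon para to a large group. With the core of compound 1 held constant, going from 5 heavy atoms and 1 hydrogen-bond acceptor in the leaving group to 4 heavy atoms and 0 hydrogen-bond acceptors in the entering group does not move the number beyond the scatter, so this pair gives no sign that this position separates these two groups in this assay. No accompanying measurement bears on this result, and the pair alone offers no explanation for it.

Among the compounds shown here, whether an amine, a carboxylic acid or a longer alkoxy chain at this position would give a step beyond the scatter remains open, since trifluoromethoxy and trifluoromethyl are the only two groups compared here. Going by these compounds, the steps involving compound 2 and compound 3 cannot be read, as each differs from the other compounds in more than one place, so the contribution of the remaining parts of these structures also remains open.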